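Triazole nitrogen substituent: cyclopropyl replacing the amino chain

This account rests on a few compounds, and the source may have more. Where it says the series, first, only, none or still open, it means among the compounds named here.

In a functional assay on HT-29 cells (Homo sapiens) for antiproliferative activity, read by MTT assay, with a stated time of 72 h (a lower number here means a stronger inhibitor, a higher number a weaker inhibitor), compound 1 `CCN(CC)CCn1cnnc1-c1cc(Oc2ccc(NC(=O)Nc3ccc(Cl)c(C(F)(F)F)c3)cc2F)ccn1` gives 900 nM, numerically the lower of the two numbers in hand; compound 2 `CCN(CC)CCn1cnnc1-c1cc(Oc2ccc(NC(=O)Nc3ccc(F)c(F)c3)cc2F)ccn1` gives 1240 nM, and the difference reads a 1.4-fold higher number from compound 1 to compound 2 (0.14 log units; within the scatter). Compound 3 `O=C(Nc1ccc(Oc2ccnc(-c3nncn3C3CC3)c2)c(F)c1)Nc1ccc(Cl)c(C(F)(F)F)c1` is not yet measured; it differs from compound 1 by cyclopropyl in place of 2-(diethylamino)ethyl on an aromatic nitrogen. For the measured compounds named here, no measured step touches this position: the only step in hand changes the group on the amide-type nitrogen. The expectation is therefore no step beyond the scatter, with wide uncertainty. Compound 3 is expected to give 900 nM in this assay, range 250 nM to 3500 nM, which means an expected no change at the digits printed from compound 1 to compound 3 (within the scatter).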

Compound 3, half-maximal inhibitory concentration: 10900 nM
Compound 3: the middle estimate sits 12-fold (1.08 log units) below what was measured, outside the stated range (above it).
By their numbers in this assay, from the lowest: compounds 1 and 2 (each within the scatter of the next); then compound 3.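

Unlike the earlier step on the amide-type nitrogen, the change on the aromatic nitrogen moves the number beyond the scatter: in this assay, cyclopropyl in place of 2-(diethylamino)ethyl gives a 12-fold higher number from compound 1 to compound 3 (1.08 log units; beyond the scatter) and is the only large step in the series so far. This position is therefore not indifferent in this assay, and compound 1 holds the lower number of the pair. Nothing available explains the step.

On these data alone, it remains open whether the amine or the chain length matters, which a plain butyl chain or a 2-(dimethylamino)ethyl group could separate. As far as these compounds go, it is also open whether the step holds with the 3,4-difluorophenyl group of compound 2.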